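The source may report more compounds than this note shows. Statements on the series, on what has been measured and on what is new or still open speak of the compounds shown alone.

Measured compounds:
- compound 1 `CC/C=C/C(=O)Nc1cc2c(N3CCc4ccccc43)ncnc2cc1OC` gives 5890 nM in a functional assay on PC-3 cells (Homo sapiens) for antiproliferative activity, read by MTT assay, with a stated time of 72 h; a lower number here means a stronger inhibitor, a higher number a weaker inhibitor
- compound 2 `CC/C=C/C(=O)Nc1cc2c(N3CCc4ccccc43)ncnc2cc1O[C@@H]1CCOC1` gives 9590 nM in this assay
- compound 3 `CC(C)=CC(=O)Nc1cc2c(N3CCCc4ccccc43)ncnc2cc1O[C@@H]1CCOC1` gives 9020 nM in this assay

Among the compounds with values here, compound 1 has the lowest of the three numbers in this assay, though neither compound 2 nor compound 3 lies beyond the scatter from it; the one single-point step available, a 1.6-fold higher number from compound 1 to compound 2 (0.21 log units; within the scatter), swaps the substituent on the ring oxygen and stays within the scatter. Compound 3 differs from compound 2 in two places at once, and its value and that of compound 2 are close to each other.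

Compound 4 `CCN(CC)C/C=C/C(=O)Nc1cc2c(N3CCc4ccccc43)ncnc2cc1OC` is derived from compound 1 by diethylamino in place of methyl on a saturated chain carbon bound to a double-bonded chain carbon. Within the data shown here, none of the measured steps touches this part of the molecule: the only step concerns the ring ether, and the difference between compound 3 and the others on the amide chain is confounded by a second change. There is therefore no measured basis for a direction, and the estimate for compound 4 is anchored on compound 1 with a broad range. Compound 4 is expected to give 4000 nM (range 800 nM to 20000 nM), a step of a 1.5-fold lower number from compound 1 to compound 4 (0.17 log units; within the scatter) that is expected to stay near the scatter.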

Compound 4, half-maximal inhibitory concentration: 3690 nM
The estimate for compound 4 lay 1.1-fold (0.04 log units) above the measured number; low and high end bracket the measured number.
By their numbers in this assay, from the lowest: compounds 4, 1, 3 and 2 (each within the scatter of the next, the first and the last beyond it).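

Diethylamino in place of methyl on a saturated chain carbon bound to a double-bonded chain carbon is the first single-point change on the amide chain, and in this assay it gives a 1.6-fold lower number from compound 1 to compound 4 (0.20 log units; within the scatter). This place therefore takes five heavy atoms, one of them nitrogen, where there was one carbon, and the number stays within the scatter of that of compound 1. No available evidence bears on this result, so nothing can be said about what underlies it.

Going by these compounds, it remains open whether dimethylamino, a piperidine or a morpholine at this place, or a longer chain carrying the amine, would give a number beyond the scatter. On these data alone, it is also open whether diethylamino gives a similar result when oxolan-3-yl replaces methyl on the ring oxygen.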